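Working notes: replacing the aryl group on the shared core

The compounds below may be only part of what the source reports. "The series", "measured", "known", "first", "only" and "open" are said of these compounds alone.

Measured so far:
compound 1 `Nc1ccccc1-c1cnc(C(=O)CCCCCCc2ccccc2)o1`, 750 nM
compound 2 `NS(=O)(=O)c1ccc(-c2cnc(C(=O)CCCCCCc3ccccc3)o2)s1`, 3 nM

In an assay (Rattus norvegicus) for inhibition of Fatty-acid amide hydrolase 1 (Homo sapiens) (a higher number here means a weaker inhibitor, a lower number a stronger inhibitor), compound 2 gives the lowest number of the two; it stands apart from compound 1 by a 250-fold lower number from compound 1 to compound 2 (2.40 log units; beyond the scatter). Compound 3 `CN(C)C(=O)c1cnc(C(=O)CCCCCCc2ccccc2)o1` differs from compound 2 by dimethylcarbamoyl in place of 5-sulfamoylthiophen-2-yl on an aromatic carbon. Within the data shown here, no measured pair exchanges an aromatic group for a carbamoyl group, so the one measured step bears on this only loosely: it shows that the group at this position can shift this assay by a large amount. Compound 3 is therefore expected to show a weaker number, estimated at 100 nM (range 20 nM to 500 nM), which would mean a 33-fold higher number from compound 2 to compound 3 (1.52 log units; beyond the scatter).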

Compound 3, inhibition constant: 2 nM
The estimate for compound 3 lay 50-fold (1.70 log units) above the measured number, outside the stated range (below it).
By their numbers in this assay, from the lowest: compounds 3 and 2 (each within the scatter of the next); then compound 1.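

In this assay, dimethylcarbamoyl, which has no ring and no hydrogen-bond donor, gives a 1.5-fold lower number from compound 2 to compound 3 (0.18 log units; within the scatter), so a low number at this aromatic carbon does not depend on the 5-sulfamoylthiophen-2-yl group. The same group gives a 380-fold lower number from compound 1 to compound 3 (2.57 log units; beyond the scatter), so the large gap between the 2-aminophenyl and non-aminophenyl compounds now holds for two quite different replacements. Nothing available accounts for the match between these two groups. The compounds shown leave open whether a carboxylic acid or a simple amine on this carbon would keep the number low. Also open, as far as these compounds go, is whether a single methyl on the amide nitrogen would serve as well as two.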